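This account rests on a few compounds, and the source may have more. Where it says the series, first, only, none or still open, it means among the compounds named here.

In an in vitro ADME assay on microsomes (Mus musculus) for metabolic stability (a higher number here means that the compound lasts longer, a lower number that the compound disappears faster), compound 1 `CNC(=O)Nc1ccc(-c2nc(N3CC4CCC(C3)O4)c3cnn(CCN(C)C)c3n2)cc1` gives 0.0833 h. Compound 2 `CNC(=O)Nc1ccc(-c2nc(N3CC4CCC(C3)O4)c3cnn(C4CCC5(CC4)OCCCO5)c3n2)cc1` gives > 0.5 h, which is a limit of the assay. Compound 3 `CNC(=O)Nc1ccc(-c2nc(N3CC4CCC(C3)O4)c3cnn([C@H]4CC[C@H](O)CC4)c3n2)cc1` gives > 0.5 h, also a limit, and so stands at the limit of > 0.5 h in this assay, at which 2 of the 3 values shown sit. Compound 4 `CNC(=O)Nc1ccc(-c2nc(N3CC4CCC(C3)O4)c3cnn(C4CCC(OC)(OC)CC4)c3n2)cc1` changes one group: a group of 10 heavy atoms (8 carbon, 2 oxygen; one six-membered non-aromatic ring of carbon only) in place of a group of 7 heavy atoms (6 carbon, 1 oxygen; one six-membered non-aromatic ring of carbon only), on an aromatic nitrogen. Among the compounds with values here, two measured steps bear on this change, an at least 6.0-fold higher number from compound 1 to compound 2 (0.77 log units; beyond the scatter) and an at least 6.0-fold higher number from compound 1 to compound 3 (0.77 log units; beyond the scatter), both beyond the scatter and both upward on leaving 2-(dimethylamino)ethyl. The third, a step that the two limits leave unreadable from compound 2 to compound 3, gives no size. Both groups that replace 2-(dimethylamino)ethyl reach the limit in this assay, so no step beyond the scatter is expected. The expected change is a step that the limit leaves unreadable from compound 3 to compound 4. For compound 4 the estimate is 0.6 h, with an expected range of 0.25 h to 1.5 h.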

Compound 4, half-life: 0.25 h
The estimate for compound 4 lay 2.4-fold (0.38 log units) above the measured number; the range from low to high includes it.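

In this assay, within the data shown here, compound 4 carries the only ring-bearing group on this aromatic nitrogen that gives a number rather than a limit, and the step from 2-(dimethylamino)ethyl is a 3.0-fold higher number from compound 1 to compound 4 (0.48 log units; beyond the scatter). Against the other two ring-bearing groups the steps are an at least 2.0-fold lower number from compound 3 to compound 4 (0.30 log units; that floor lies within the scatter) and an at least 2.0-fold lower number from compound 2 to compound 4 (0.30 log units; that floor lies within the scatter), so neither floor establishes a real loss. Compounds 2 and 3 remain limits: the limit of > 0.5 h in this assay, at which 2 of the 4 values shown sit.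

As far as these compounds go, how far compounds 2 and 3 actually lie from compound 4 stays open. So does how a 4-aminocyclohexyl group would read at this position.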